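Ortho-methyl for para-methyl on the anilino group

The source may hold more compounds than are shown below. What is called first, only, known or untested is meant among the compounds shown, and "the series" means these compounds.

This account follows the change from compound 2 to compound 4. Compound 2 `Cc1ccc(Nc2nc(N)nc(CSc3nc4ccccc4[nH]3)n2)cc1` carries a 4-methylphenyl group on the anilino nitrogen; in an ADME assay on Vero cells (Chlorocebus sabaeus) for cytotoxicity, read by resazurin assay, with a stated time of 3 days (on this read-out higher numbers stand for lower toxicity in this test and lower numbers for higher toxicity in this test), compound 2 stands at "not determined" (no result reported), so no number anchors it. Compound 4 `Cc1ccccc1Nc1nc(N)nc(CSc2nc3ccccc3[nH]2)n1` differs from it in one place: 2-methylphenyl in place of 4-methylphenyl on a nitrogen on an aromatic ring.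

Among the compounds with values here, the one measured step that resembles this change sits on another core. Compound 1 `COc1ccc(Nc2nc(N)nc(CSc3nnc(-c4ccncc4)n3-c3ccccc3)n2)cc1` gives 1500 ug/mL in this assay, and compound 3 `Cc1ccccc1Nc1nc(N)nc(CSc2nnc(-c3ccncc3)n2-c2ccccc2)n1` gives 1650 ug/mL; the step of a 1.1-fold higher number from compound 1 to compound 3 (0.04 log units; within the scatter) is within the scatter. Within the data shown here, there a 2-methylphenyl group replaced a 4-substituted phenyl on the same kind of nitrogen without a shift beyond the scatter, which argues for no step of note here either, though the core of compound 2 has no measured value of its own to lean on.

Compound 4 is therefore expected to give about 1500 ug/mL in this assay, with a range from 800 ug/mL to 2600 ug/mL, resting on compound 1 at 1500 ug/mL and compound 3 at 1650 ug/mL.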

Compound 4, half-maximal cytotoxic concentration: > 2000 ug/mL
Compound 4: only a limit was reported; the forecaster's own chance of this, stated with the estimate: 25%; middle value at least 1.3-fold (0.12 log units) away from the limit.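

In this assay compound 4 gives > 2000 ug/mL, which is a limit and not a number. With compound 2 at "not determined" (no result reported), no step can be read between compound 2 and compound 4. The compounds shown leave open how far 2-methylphenyl in place of 4-methylphenyl moves the read-out on this core.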